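Working notes: aryl exchange from compound 3 to compound 4

A few compounds are considered here, and "the series" means these few. Any claim that something is new, unique, unknown or untested is made for them only; others in the source may bear on it.

Series in a functional assay on HepG2 cells (Homo sapiens) for cytotoxicity, read by MTT assay, with a stated time of 48 h; a lower number here means a stronger inhibitor, a higher number a weaker inhibitor
- compound 1 `COc1ccc(-c2nnc(SCCn3c([N+](=O)[O-])cnc3C)o2)cc1` gives 5800 nM
- compound 2 `Cc1ncc([N+](=O)[O-])n1CCSc1nnc(-c2ccc(N)cc2)o1` gives 6700 nM
- compound 3 `Cc1ncc([N+](=O)[O-])n1CCSc1nnc(-c2ccccc2Cl)o1` gives 15600 nM
- compound 4 `Cc1ccc(-c2nnc(SCCn3c([N+](=O)[O-])cnc3C)o2)c(O)c1` is not yet measured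

Compound 3 has the highest number of the three at 15600 nM. The next change is 2-hydroxy-4-methylphenyl in place of 2-chlorophenyl on an aromatic carbon with 2-hydroxy-4-methylphenyl in place of 2-chlorophenyl on an aromatic carbon. Among the compounds with values here, no measured compound carries this new group. The nearest evidence is two modest steps that end on 2-chlorophenyl: a 2.7-fold higher number from compound 1 to compound 3 (0.43 log units; beyond the scatter) and a 2.3-fold higher number from compound 2 to compound 3 (0.37 log units; beyond the scatter). The exchange of amino for methoxy stayed small: a 1.2-fold higher number from compound 1 to compound 2 (0.06 log units; within the scatter). In this assay a modest move to a lower number is therefore expected. The expected step is a 2.0-fold lower number from compound 3 to compound 4 (0.29 log units; within the scatter). The estimate for compound 4 is 8000 nM with an expected range of 3000 nM to 20000 nM.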

Compound 4, half-maximal inhibitory concentration: 16600 nM
The estimate for compound 4 lay 2.1-fold (0.32 log units) below the measured number; measured number inside the range.
By their numbers in this assay, from the lowest: compounds 1 and 2 (each within the scatter of the next); then compounds 3 and 4 (each within the scatter of the next).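

In this assay, exchanging 2-chlorophenyl for 2-hydroxy-4-methylphenyl on this aromatic carbon leaves the number within the scatter, a 1.1-fold higher number from compound 3 to compound 4 (0.03 log units; within the scatter), although a hydrogen-bond donor and acceptor enter with the new group. 2-Hydroxy-4-methylphenyl thus stays with 2-chlorophenyl and apart from the other two aryl groups, with a 2.5-fold higher number from compound 2 to compound 4 (0.39 log units; beyond the scatter) and a 2.9-fold higher number from compound 1 to compound 4 (0.46 log units; beyond the scatter). No supporting measurement bears on why these groups fall together.

The compounds shown leave open whether the hydroxy or the methyl of the new group matters here. A plain phenyl or a 2-carboxyphenyl at this position would test how far this grouping holds.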